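A few compounds are considered here, and "the series" means these few. Any claim that something is new, unique, unknown or untested is made for them only; others in the source may bear on it.

Compound 1 `Oc1cccc(-c2cc(-c3ccc(Cl)cc3)nc(-c3ccccn3)c2)c1` is one of three compounds carrying a hydroxyphenyl group, a chlorophenyl group and a pyridyl group on a shared core. In a functional assay on HCT-15 cells (Homo sapiens) for cytotoxicity, read by CCK-8 assay and cell counting, with a stated time of 2 days (on this read-out higher numbers stand for weaker inhibition and lower numbers for stronger inhibition), compound 1 gives 13500 nM. Compound 3 `Oc1ccc(-c2cc(-c3ccc(Cl)cc3)nc(-c3ccccn3)c2)cc1` differs only in the hydroxyphenyl group and gives 21300 nM in this assay; the step of a 1.6-fold higher number from compound 1 to compound 3 (0.20 log units; within the scatter) shows that compound 1 and compound 3 sit within the usual scatter of each other, so neither can be called more or less potent. Compound 2 `Oc1cccc(-c2cc(-c3ccccn3)nc(-c3ccccc3Cl)c2)c1` has been made, but in this assay its result is "not determined" (no result reported), so it adds no number to the picture.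

Compound 4 `Oc1cccc(-c2cc(-c3ccncc3)nc(-c3ccc(Cl)cc3)c2)c1` differs from compound 1 in the pyridyl group: pyridin-4-yl in place of pyridin-2-yl on an aromatic carbon. Among the measured compounds shown here, no measured step bears on this change; the only step available concerns the hydroxyphenyl group and stays within the scatter. There is therefore no basis for expecting a shift in either direction beyond the scatter, and the step of a 1.0-fold higher number from compound 1 to compound 4 (0.02 log units; within the scatter) is expected to be small. Compound 4 is estimated to give 14000 nM in this assay, with a range from 4000 nM to 50000 nM reflecting the weak numbers seen so far and the absence of any directly comparable step.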

Compound 4, half-maximal inhibitory concentration: 2630 nM
Beside the measured number, compound 4's estimate is 5.3-fold (0.73 log units) above it; measured number below the stated range.
By their numbers in this assay, from the lowest: compound 4; then compounds 1 and 3 (each within the scatter of the next).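

Among the compounds shown here, replacing pyridin-2-yl with pyridin-4-yl gives a 5.1-fold lower number from compound 1 to compound 4 (0.71 log units; beyond the scatter) in this assay, the first step to lie beyond the scatter, whereas the earlier change on the hydroxyphenyl group gave only a 1.6-fold higher number from compound 1 to compound 3 (0.20 log units; within the scatter). The two pyridyl groups have the same heavy atoms and the same counts of hydrogen-bond donors and acceptors, so this pair shows that the number can shift with the way the atoms of the group are joined, even when those counts do not change. No measurement offered here explains why this change lowers the number.

Pyridin-3-yl, an amine and a carboxylic acid are not among the compounds shown, so how any of them would behave at this position stays open. Going by these compounds, this step also rests on a single pair, so it remains unknown whether the same pyridyl change would lower the number to a similar extent with 4-hydroxyphenyl in place of 3-hydroxyphenyl on the shared core.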